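Tolerance notes: 1,2-thiazol-4-yl replacing 4-chloro-3-fluorophenyl

The source may hold more compounds than are shown below. What is called first, only, known or untested is meant among the compounds shown, and "the series" means these compounds.

Compound 1: `COc1nc(-c2ccc(OC(F)(F)F)cc2)ccc1[C@@H](c1ccccc1)[C@@](O)(CCN(C)C)c1cccc2ccccc12` — > 64 ug/mL
Compound 2: `COc1nc(-c2ccc(Cl)c(F)c2)ccc1[C@@H](c1ccccc1)[C@@](O)(CCN(C)C)c1cccc2ccccc12` — > 64 ug/mL

In a toxicity assay on HeLa cells (Homo sapiens) for cytotoxicity (a lower number here means that less compound is tolerated, a higher number that more compound is tolerated), compound 1 gives > 64 ug/mL, which is a limit of the assay and not a number. In this assay compound 2 likewise gives > 64 ug/mL, again only a limit. Within the data shown here, the single measured step, a step that the two limits leave unreadable from compound 1 to compound 2, is therefore not readable; both values sit at the limit of > 64 ug/mL in this assay, at which 2 of the 2 values shown sit. Among the measured compounds shown here, compound 2 thus stands at the limit, and the one further value shown is a limit as well.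

Compound 3, `COc1nc(-c2cnsc2)ccc1[C@@H](c1ccccc1)[C@@](O)(CCN(C)C)c1cccc2ccccc12`, differs from compound 2 by 1,2-thiazol-4-yl in place of 4-chloro-3-fluorophenyl on an aromatic carbon. For the measured compounds named here, the only step that bears on this change is a step that the two limits leave unreadable from compound 1 to compound 2, and it shows merely that exchanging the group at this place kept the value at the limit. For compound 3 the expectation in this assay is 80 ug/mL, within 40 ug/mL to 160 ug/mL, most likely reported again as a limit. The step that the limit leaves unreadable from compound 2 to compound 3 is expected to show no change beyond the scatter.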

Compound 3, half-maximal cytotoxic concentration: 28.8 ug/mL
Estimate against measurement, compound 3: 2.8-fold (0.44 log units) above, outside the stated range (below it).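

In this assay this position is shown for the first time not to be indifferent to the group it carries: 1,2-thiazol-4-yl in place of 4-chloro-3-fluorophenyl gives an at least 2.2-fold lower number from compound 2 to compound 3 (0.34 log units; beyond the scatter). The same group in place of 4-(trifluoromethoxy)phenyl gives an at least 2.2-fold lower number from compound 1 to compound 3 (0.34 log units; beyond the scatter), whereas the step between the two substituted phenyl groups cannot be read. Both readable steps give only a minimum size, and the two phenyl compounds remain at the assay limit: the limit of > 64 ug/mL in this assay, at which 2 of the 3 values shown sit.

The change alters ring size, heavy-atom count, hydrogen-bond acceptors and halogen content at once, so the compounds shown do not separate these features. On these data alone, whether the lower number follows the sulfur-containing five-membered ring or the loss of the halogenated phenyl stays open, a question that an unsubstituted phenyl or a pyridin-3-yl at this position would address.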